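Swapping Triazole for Tetrazole on a Shared Core

The source may report more compounds than this note shows. Statements on the series, on what has been measured and on what is new or still open speak of the compounds shown alone.

Three compounds built on one shared core were tested in an assay for inhibition of Aromatase (Homo sapiens), tested at 20 uM; on this read-out lower numbers stand for less inhibition and higher numbers for more inhibition at the one concentration tested (going by the name of the read-out). Compound 1, `O=[N+]([O-])c1ccc2c(c1)CC(C(c1ccccc1)n1cncn1)O2`, gives 58.4%. Compound 2, `Cc1ccc(C(C2Cc3ccccc3O2)n2cncn2)cc1`, gives 96.8%. Compound 3, `Clc1ccc(C(C2Cc3ccccc3O2)n2cncn2)c(Cl)c1`, gives 97.7%, the highest of the three numbers, although its gap to compound 2 lies within the usual scatter, while its gap to compound 1 lies beyond it. Compound 4, `Clc1ccc(C(C2Cc3ccccc3O2)n2cnnn2)c(Cl)c1`, has not yet been measured; it differs from compound 3 by 1H-tetrazol-1-yl in place of 1H-1,2,4-triazol-1-yl on a saturated chain carbon bound to an aromatic carbon and a saturated ring carbon. Going by the values given here, no step between measured compounds covers this change, so the expectation rests on compound 3 alone. Compound 4 is expected to give 88% (range 65% to 99%) in this assay. The expected step of a number 9.7 percentage points lower from compound 3 to compound 4 (within the scatter) is a modest decrease that may still fall within the scatter.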

Compound 4, a percentage reported as inhibition, at one concentration (the size of the read-out at that concentration, not a potency): 82.3%
For compound 4 the middle estimate is 5.7 percentage points above the measured one; measured number inside the range.
By their numbers in this assay, from the lowest: compound 1; then compound 4; then compounds 2 and 3 (each within the scatter of the next).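

On the saturated chain carbon bound to an aromatic carbon and a saturated ring carbon, 1H-tetrazol-1-yl in place of 1H-1,2,4-triazol-1-yl gives a number 15.4 percentage points lower from compound 3 to compound 4 (beyond the scatter) in this assay. This position therefore responds to a change of a single ring atom, although compound 4 still shows 82.3% inhibition at the one concentration tested. Nothing measured here explains the drop.

Going by these compounds, how an imidazole ring or a simple amine on this same carbon would read out remains open. So does whether the same swap would give a similar step on compound 2 or compound 1.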